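The compounds below may be only part of what the source reports. "The series", "measured", "known", "first", "only" and "open" are said of these compounds alone.

Compound 2 `CCCC[C@H](NC(=O)[C@H](CCCCN)NC(=O)[C@H](CCCNC(=N)N)NC(=O)c1ccc(/C=C2\SC(=S)N(Cc3ccc(OC)cc3)C2=O)cc1)C(N)=O` is one of two peptide-like compounds measured in an ADME assay for permeability, using PAMPA (on this read-out lower numbers stand for lower permeability and higher numbers for higher permeability), where compound 2 gives 0.6 10^-6 cm/s. Compound 1 `CCCC[C@@H](NC(=O)[C@@H](CCCCN)NC(=O)[C@@H](CCCNC(=N)N)NC(=O)c1ccc(/C=C2\SC(=O)N(Cc3ccccc3)C2=O)cc1)C(N)=O` gives 0.29 10^-6 cm/s in this assay, so compound 2 holds the higher of the two numbers, and that gap is beyond the usual scatter. Compound 3 `CCCC[C@H](NC(=O)[C@H](CCCCN)NC(=O)[C@H](CCCNC(=N)N)NC(=O)c1ccc(/C=C2\SC(=S)N(C3CCCCC3)C2=O)cc1)C(N)=O` has not yet been measured; it differs from compound 2 by cyclohexyl in place of 4-methoxybenzyl on an amide-type nitrogen in a ring. Among the measured compounds shown here, with no measured pair showing this exact change, the step of no change at the digits printed from compound 2 to compound 3 (within the scatter) is expected to stay within the scatter. Compound 3 is therefore estimated at 0.6 10^-6 cm/s, with a range from 0.3 10^-6 cm/s to 1.2 10^-6 cm/s.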

Compound 3, apparent permeability: 1.82 10^-6 cm/s
Compound 3: the middle estimate sits 3.0-fold (0.48 log units) below what was measured, and the stated range ends below it.
By their numbers in this assay, from the lowest: compound 1; then compound 2; then compound 3.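

In this assay, cyclohexyl in place of 4-methoxybenzyl on the amide-type nitrogen in the ring gives a 3.0-fold higher number from compound 2 to compound 3 (0.48 log units; beyond the scatter), showing that this position alone can move the read-out beyond the scatter. The change removes an aromatic ring and a hydrogen-bond acceptor, but this single pair cannot show which of these differences matters. No measured evidence here bears on the reason for the rise. The compounds shown leave open whether a phenyl group or a linear hexyl chain at this nitrogen would match cyclohexyl. From the compounds shown here alone, whether the step would hold on the core of compound 1 also remains open.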